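Adding a Second Fluorine to the Piperidine Ring

The source may hold more compounds than are shown below. What is called first, only, known or untested is meant among the compounds shown, and "the series" means these compounds.

Compound 1, `Nc1nc(-c2ccco2)nc2sc(CN3CCC(F)(F)CC3)cc12`: 2230 nM
Compound 2, `C[C@@H]1CCC[C@H](C)N1Cc1cc2c(N)nc(-c3ccc(C(F)F)o3)nc2s1`: 730 nM
Compound 3, `Nc1nc(-c2ccc(C(F)F)o2)nc2sc(CN3CCC(F)CC3)cc12`: 1670 nM

These three compounds were measured in an assay on CHO-K1 cells for antagonist activity at adenosine receptor A1 (Homo sapiens), read by a beta-galactosidase reporter, with stated times of 15 min and 6 h; on this read-out higher numbers stand for weaker inhibition and lower numbers for stronger inhibition. Among them compound 3 has the second highest number: its value and that of compound 1 lie within the scatter of each other, while compound 2 stands apart, as the step of a 2.3-fold higher number from compound 2 to compound 3 (0.36 log units; beyond the scatter) shows. Among the measured compounds shown here, that step, the only one measured between compounds differing in a single place, concerns the amine as a whole and not a change inside the piperidine ring.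

Compound 4, `Nc1nc(-c2ccc(C(F)F)o2)nc2sc(CN3CCC(F)(F)CC3)cc12`, differs from compound 3 by fluoro in place of hydrogen on a saturated ring carbon. For the measured compounds named here, no measured pair isolates this change. Compound 1 carries the same 4,4-difluoropiperidin-1-yl group as compound 4, but it also differs from compound 3 in the furan substituent, and the numbers of compound 1 and compound 3 agree within the scatter. With nothing pointing to a shift in either direction, the step is expected to be small: for compound 4 the estimate is a 1.1-fold higher number from compound 3 to compound 4 (0.03 log units; within the scatter), that is a value of about 1800 nM, expected to fall between 900 nM and 3600 nM.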

Compound 4, inhibition constant: 17800 nM
Compound 4: middle estimate off by 9.9-fold (1.00 log units), on the low side, outside the stated range (above it).
By their numbers in this assay, from the lowest: compound 2; then compounds 3 and 1 (each within the scatter of the next); then compound 4.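

In this assay, among the compounds shown here, the ring carbon three ring bonds from the ring nitrogen proves sensitive to a single atom: with fluoro in place of hydrogen there, the result is an 11-fold higher number from compound 3 to compound 4 (1.03 log units; beyond the scatter), a large move toward weaker inhibition that no earlier pair could isolate. The change of amine therefore depends strongly on which piperidine enters, since replacing 2,6-dimethylpiperidin-1-yl gives the modest 2.3-fold higher number from compound 2 to compound 3 (0.36 log units; beyond the scatter) with 4-fluoropiperidin-1-yl but the large 24-fold higher number from compound 2 to compound 4 (1.39 log units; beyond the scatter) with 4,4-difluoropiperidin-1-yl. With 4,4-difluoropiperidin-1-yl held constant, difluoromethyl in place of hydrogen on an aromatic carbon also proves to matter, giving an 8.0-fold higher number from compound 1 to compound 4 (0.90 log units; beyond the scatter), again toward weaker inhibition.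

No measurement offered here explains why the second fluorine has so large an effect. The compounds shown leave open whether a hydroxyl or a methyl group on that same ring carbon would produce a step of similar size, and whether the difluoromethyl step would keep its size with 4-fluoropiperidin-1-yl in place of 4,4-difluoropiperidin-1-yl.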